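A few compounds are considered here, and "the series" means these few. Any claim that something is new, unique, unknown or untested is made for them only; others in the source may bear on it.

Two compounds of the series have numbers in a toxicity assay on Vero C1008 cells (Chlorocebus sabaeus) for cytotoxicity, read by neutral red uptake, with a stated time of 5 days; a higher number here means that more compound is tolerated, a lower number that less compound is tolerated. Compound 1 `CC(C)(C)c1ccc(N(C(=O)c2ccco2)C(C(=O)NC2CCCC2)c2cccnc2)cc1` gives 101000 nM there. Compound 2 `C[C@H](NC(=O)C(c1cccnc1)N(C(=O)c1ccco1)c1ccc(-c2ccco2)cc1)c1ccccc1` gives 56400 nM in this assay. Compound 2 holds the lowest of the two numbers, yet its nearest neighbour is compound 1 and the gap between them lies within the scatter, so the two are read as level rather than ordered. Within the data shown here, no step between measured compounds that differ in one place is available in this set.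

Compound 3 `C[C@H](NC(=O)C(c1cccnc1)N(C(=O)c1ccco1)c1ccc(-c2ccccc2)cc1)c1ccccc1` has not yet been measured in this assay. Its change from compound 2 is phenyl in place of furan-2-yl on an aromatic carbon; the same difference, cut one bond further out, reads 4-(furan-2-yl)phenyl to 4-phenylphenyl, sitting on an aromatic carbon of a six-membered aromatic ring of carbon only, para to a large group.

Among the measured compounds shown here, nothing among the measured pairs speaks to this change, so no step beyond the scatter is expected in this assay in either direction. Compound 3 is estimated at 50000 nM, with a range of 20000 nM to 120000 nM. The estimated step of a 1.1-fold lower number from compound 2 to compound 3 (0.05 log units; within the scatter) is expected to stay within the scatter.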

Compound 3, half-maximal cytotoxic concentration: > 200000 nM
Compound 3 ended at the assay's limit (the forecaster's own chance of this, stated with the estimate: 5%); middle value at least 4.0-fold (0.60 log units) from the limit.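

Among these compounds, the change of furan-2-yl to phenyl, on an aromatic carbon of a six-membered aromatic ring of carbon only, para to a large group, is the first one-place change readable. In this assay it gives an at least 3.5-fold higher number from compound 2 to compound 3 (0.54 log units; beyond the scatter), so the group at this position is not silent in this assay, and the step runs towards more compound being tolerated with phenyl than with furan-2-yl. Compound 3 stands at a limit of the assay, so the step gives a minimum size and not a measured one: the limit of > 200000 nM in this assay, at which 1 of the 3 values shown sits.

The compounds shown give no reason for the step, and they leave open whether it comes from the loss of furan-2-yl or the arrival of phenyl, and whether it would hold with the cyclopentyl amide of compound 1 in place of the chiral 1-phenylethyl amide. They also leave open how this position responds to a group of another kind, such as a dimethylamino group, a carboxylic acid or a longer alkyl chain on the same ring carbon.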